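A few compounds are considered here, and "the series" means these few. Any claim that something is new, unique, unknown or untested is made for them only; others in the source may bear on it.

Values in an ADME assay on HepG2 cells (Homo sapiens) for cytotoxicity, read by MTT assay (a lower number here means a stronger inhibitor, a higher number a weaker inhibitor), follow, each of them a limit of the assay and not a number:
Compound 1 `O=C(NCc1ccccc1)Oc1ccc(Cl)cc1C(=O)Nc1ccc(Cl)cc1` gives > 250000 nM
Compound 2 `O=C(Nc1ccccc1)Oc1ccc(Cl)cc1C(=O)Nc1ccc(Br)cc1` gives > 50000 nM
Compound 3 `O=C(NCc1ccccc1)Oc1ccc(Cl)cc1C(=O)Nc1ccc(C(F)(F)F)cc1` gives > 125000 nM

Compound 3 has only the limit > 125000 nM to show in this assay, and the other two compounds offer no number either. Compound 4 `O=C(NCc1ccccc1)Oc1ccc(Cl)cc1C(=O)Nc1ccc(Br)cc1` changes one place: bromo in place of trifluoromethyl on an aromatic carbon, para to a large group. For the measured compounds named here, the one measured step that bears on this is a step that the two limits leave unreadable from compound 1 to compound 3, which gives no size to carry over. No direction can be read from these limits, so the expected change in this assay is a step that the limit leaves unreadable from compound 3 to compound 4, none beyond the scatter. Compound 4 is expected near 150000 nM, with an estimated range from 60000 nM to 300000 nM, most likely again as a limit.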

Compound 4, half-maximal inhibitory concentration: > 50000 nM
Compound 4: a limit, no number (the forecaster's own chance of this, stated with the estimate: 85%); the middle value does not contradict the limit.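

For the compounds shown here, compound 4 stands only as a limit, like compounds 1, 2 and 3, so no step between these compounds can be read. The compounds shown leave open how any of the changes affects cytotoxicity in this assay.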